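Bigger Amine Ring on the Sulfonyl Sulfur: Clearance Outlook

The source may hold more compounds than are shown below. What is called first, only, known or untested is meant among the compounds shown, and "the series" means these compounds.

Compound 1, `O=C(NCc1ccc(S(=O)(=O)C2CCCOC2)cc1)N1Cc2ccncc2C1`: 7 mL/min/kg
Compound 2, `O=C(NCc1ccc(S(=O)(=O)N2CCC[C@H](O)C2)cc1)N1Cc2ccncc2C1`: 8 mL/min/kg
Compound 3, `CN1CCN(S(=O)(=O)c2ccc(CNC(=O)N3Cc4ccncc4C3)cc2)CC1`: 9 mL/min/kg

Of the compounds shown here, three sharing one core have been measured in an ADME assay on microsomes from liver (Homo sapiens) for pharmacokinetics, read by LC-MS, with a stated time of 60 min, tested at 1 uM; on this read-out lower numbers stand for slow clearance and higher numbers for fast clearance. Compound 1 gives the lowest number written down, but the steps to its neighbours, a 1.1-fold higher number from compound 1 to compound 2 (0.06 log units; within the scatter) and a 1.3-fold higher number from compound 1 to compound 3 (0.11 log units; within the scatter), are within the scatter, and so is a 1.1-fold higher number from compound 2 to compound 3 (0.05 log units; within the scatter); the three cannot be told apart.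

The new compound 4, `O=C(NCc1ccc(S(=O)(=O)N2CCC(N3CCCC3)CC2)cc1)N1Cc2ccncc2C1`, differs from compound 1 in one place: 4-(pyrrolidin-1-yl)piperidin-1-yl in place of oxan-3-yl on a sulfonyl sulfur. Two of the measured steps bear on this, since both replaced oxan-3-yl on the sulfonyl sulfur with a nitrogen-linked ring and gave a 1.1-fold higher number from compound 1 to compound 2 (0.06 log units; within the scatter) and a 1.3-fold higher number from compound 1 to compound 3 (0.11 log units; within the scatter), neither beyond the scatter. Going by the values given here, compound 4 brings a larger ring pair than either, and no measured step covers a group of this size, so a slightly higher number is plausible but not required. The expected step for compound 4 is a 1.4-fold higher number from compound 1 to compound 4 (0.15 log units; within the scatter), not beyond the scatter. Compound 4 is therefore estimated at 10 mL/min/kg, in a range from 5 mL/min/kg to 20 mL/min/kg.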

Compound 4, clearance: 6 mL/min/kg
For compound 4 the middle estimate is 1.7-fold (0.22 log units) above the measured one; the measured number falls inside the stated range.
By their numbers in this assay, from the lowest: compounds 4, 1, 2 and 3 (each within the scatter of the next).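

Going by these compounds alone, the earlier compounds carried only one ring on the sulfonyl sulfur, whereas 4-(pyrrolidin-1-yl)piperidin-1-yl brings two, and in (this assay) the number still stays level with the others (a 1.2-fold lower number from compound 1 to compound 4 (0.07 log units; within the scatter); a 1.3-fold lower number from compound 2 to compound 4 (0.12 log units; within the scatter); a 1.5-fold lower number from compound 3 to compound 4 (0.18 log units; within the scatter)). Going from one ring to two at this place therefore gives no step beyond the scatter in these four compounds. No supporting measurement bears on why the number holds level.

The compounds shown leave open whether a different kind of group on the sulfonyl sulfur, such as a carboxylic acid or an open-chain amine, would move the number beyond the scatter. Within the data shown here, since no compound here stands apart from the others, which features of the group matter for clearance, if any, also remains unknown.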